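Swapping Cyclopropyl for 4-Cyanophenyl on the Sulfonyl

A few compounds are considered here, and "the series" means these few. Any claim that something is new, unique, unknown or untested is made for them only; others in the source may bear on it.

Three compounds have been measured in a functional assay on MDA-MB-231 cells (Homo sapiens) for inhibition, read by sulforhodamine B assay, tested at 10 uM; a lower number here means less inhibition, a higher number more inhibition at the concentration tested (going by the name of the read-out):

Compound 1 `CN1CCN(c2ccc(C3=NNC(c4ccc(N(C)C)cc4)C3)cc2)CC1` gives 11.4%
Compound 2 `CN1CCN(c2ccc(C3=NN(C(=O)c4ccc(C(F)(F)F)cc4)C(c4ccc(N(C)C)cc4)C3)cc2)CC1` gives 55.4%
Compound 3 `CN1CCN(c2ccc(C3=NN(S(=O)(=O)C4CC4)C(c4ccc(N(C)C)cc4)C3)cc2)CC1` gives 3.7%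

On these numbers compound 3 sits at the bottom, but a number 7.7 percentage points lower from compound 1 to compound 3 (within the scatter) lies within the usual scatter, so compound 1 and compound 3 cannot be separated. Against compound 2 the gap is real: a number 51.7 percentage points lower from compound 2 to compound 3 (beyond the scatter).

Compound 4 `CN1CCN(c2ccc(C3=NN(S(=O)(=O)c4ccc(C#N)cc4)C(c4ccc(N(C)C)cc4)C3)cc2)CC1` is the next step from compound 3. The change is 4-cyanophenyl in place of cyclopropyl on a sulfonyl sulfur.

Going by the values given here, two measured steps bear on it. Attaching a group that carries an aromatic ring to the ring nitrogen gave a number 44 percentage points higher from compound 1 to compound 2 (beyond the scatter), while exchanging that group for cyclopropylsulfonyl gave a number 51.7 percentage points lower from compound 2 to compound 3 (beyond the scatter). In both steps, the compound bearing an aromatic ring on the substituent came out far higher. Among the compounds with values here, no compound with an aromatic ring on the sulfonyl sulfur has been measured, so the size of the step is uncertain, but the direction suggested is upward.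

Compound 4 is therefore expected to show a rise beyond the scatter, a number 26.3 percentage points higher from compound 3 to compound 4 (beyond the scatter), in this assay. The estimated value for compound 4 is 30%, with a range from 5% to 60%.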

Compound 4, a percentage reported as inhibition, at one concentration (the size of the read-out at that concentration, not a potency): 99.8%
Estimate against measurement, compound 4: 69.8 percentage points below; the measured number lies above the stated range.
By their numbers in this assay, from the lowest: compounds 3 and 1 (each within the scatter of the next); then compound 2; then compound 4.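

Placing 4-cyanophenyl on the sulfonyl sulfur in place of cyclopropyl gives a number 96.1 percentage points higher from compound 3 to compound 4 (beyond the scatter) in this assay, so a sulfonyl at this ring nitrogen does not by itself keep the number low, and the group carried on the sulfur decides a great deal. The sulfonyl series can also exceed the carbonyl example, with (4-cyanophenyl)sulfonyl in place of (4-(trifluoromethyl)phenyl)carbonyl giving a number 44.4 percentage points higher from compound 2 to compound 4 (beyond the scatter), while the same group in place of hydrogen on the ring nitrogen gives a number 88.4 percentage points higher from compound 1 to compound 4 (beyond the scatter). Nothing at hand explains why this exchange has such a large effect.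

The step from compound 2 to compound 4 changes both the link to the ring nitrogen and the substituent on the aromatic ring, so the share of each remains unresolved, as does whether the aromatic ring or its nitrile accounts for the rise from cyclopropyl. An unsubstituted phenyl on the sulfonyl sulfur, or a phenyl carrying an amine or a methoxy group at the same place, would help to separate those two contributions.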